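The source may report more compounds than this note shows. Statements on the series, on what has been measured and on what is new or still open speak of the compounds shown alone.

Compound 1 `O=C(/C=C/c1ccc([N+](=O)[O-])o1)c1ccc(-n2ccnc2)cc1`: in an ADME assay on Vero cells (Chlorocebus sabaeus) for cytotoxicity, read by resazurin assay, with a stated time of 72 h (a higher number here means that more compound is tolerated, a lower number that less compound is tolerated), compound 1 reaches only > 100000 nM, which is a limit of the assay and not a number.
Compound 2 `CCCCc1ccc(C(=O)/C=C/c2ccc([N+](=O)[O-])o2)cc1`: in this assay compound 2 gives 75700 nM.

Among the measured compounds shown here, compound 2 thus holds the only number in this set; the other value sits at the limit of > 100000 nM in this assay, at which 1 of the 2 values shown sits. Compound 3 `O=C(/C=C/c1ccc([N+](=O)[O-])o1)c1ccc(N2CCNCC2)cc1` is not yet measured. It differs from compound 2 by piperazin-1-yl in place of butyl on an aromatic carbon. For the measured compounds named here, only one measured step exists: an at least 1.3-fold lower number from compound 1 to compound 2 (0.12 log units; that floor lies within the scatter), too small to lie beyond the scatter. The change to compound 3 runs the other way, putting piperazin-1-yl where the butyl stood, and because an at least 1.3-fold lower number from compound 1 to compound 2 (0.12 log units; that floor lies within the scatter) stayed within the scatter, only a modest shift upward in this assay is expected here. Compound 3 is therefore estimated at 100000 nM, between 50000 nM and 200000 nM. That estimate means a step of a 1.3-fold higher number from compound 2 to compound 3 (0.12 log units; within the scatter), which may end at the limit rather than at a number.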

Compound 3, half-maximal cytotoxic concentration: > 100000 nM
Compound 3 gave a limit, no number; the forecaster's own chance of this, stated with the estimate: 45%; the middle value lies on the limit itself.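

Putting piperazin-1-yl in place of butyl on this aromatic carbon gives an at least 1.3-fold higher number from compound 2 to compound 3 (0.12 log units; that floor lies within the scatter), so this change, like the earlier one, cannot be shown to go beyond the scatter. In this assay the value of compound 3 is a limit, which makes piperazin-1-yl the second group at this position, after 1H-imidazol-1-yl, to end at a limit, while only butyl gives a number: the limit of > 100000 nM in this assay, at which 2 of the 3 values shown sit. The step from compound 1 to compound 3 cannot be read, as both values are limits.

The compounds shown leave open whether compound 2 truly differs from compound 1 and compound 3, and how far the two limits lie from its number. A longer alkyl chain, an open-chain amine or a carboxylic acid at this position would test whether butyl stands alone here.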